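The source may hold more compounds than are shown below. What is called first, only, known or untested is meant among the compounds shown, and "the series" means these compounds.

Working notes on the series. The shared core is that of compound 1 `CCC(C)(C)Cc1c[nH]c(CCc2ccc(-c3csnn3)cc2)n1`; compound 2 `CCC(C)(C)Cc1c[nH]c(CCc2ccc(-n3ncnn3)cc2)n1` and compound 3 `O=C(O)c1cc(F)c(F)cc1-c1ccc(CCc2nc(CC3CCCCC3)c[nH]2)cc1` carry other groups on the six-membered aromatic ring. In a functional assay on HEK293 cells for agonist activity at Bombesin receptor subtype-3 (Homo sapiens), read by luminescence and calcium flux, with a stated time of 10 min (on this read-out higher numbers stand for an effect only at larger amounts of compound and lower numbers for an effect already at smaller amounts), compound 1 gives 538 nM, compound 2 gives 422 nM and compound 3 gives 63 nM. Compound 2 thus stands second highest of the three numbers, with compound 1 nearest and compound 3 lower and beyond the scatter. Compound 4 `CCC(C)(C)Cc1c[nH]c(CCc2ccc(-c3ccns3)cc2)n1` differs from compound 2 by 1,2-thiazol-5-yl in place of 2H-tetrazol-2-yl on an aromatic carbon. Among the compounds with values here, the one step that bears on this, a 1.3-fold lower number from compound 1 to compound 2 (0.11 log units; within the scatter), exchanged one five-membered aromatic ring for another on the same aromatic carbon and stayed within the scatter; the change to compound 4 is of the same kind, so no step beyond the scatter is expected in this assay. Compound 4 is therefore estimated at 450 nM (range 200 nM to 1000 nM), an expected step of a 1.1-fold higher number from compound 2 to compound 4 (0.03 log units; within the scatter).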

Compound 4, half-maximal effective concentration: 63 nM
Estimate against measurement, compound 4: 7.1-fold (0.85 log units) above; the measured number lies below the stated range.
By their numbers in this assay, from the lowest: compounds 3 and 4 (each within the scatter of the next); then compounds 2 and 1 (each within the scatter of the next).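

On an aromatic carbon para to a large group, the five-membered aromatic rings are not interchangeable: in this assay, 1,2-thiazol-5-yl gives a 6.7-fold lower number from compound 2 to compound 4 (0.83 log units; beyond the scatter) and an 8.5-fold lower number from compound 1 to compound 4 (0.93 log units; beyond the scatter), although the exchange between the other two rings stayed within the scatter. Both 2H-tetrazol-2-yl and 1,2-thiazol-5-yl count 5 heavy atoms, so this step comes without a change in that count. Nothing available accounts for the step. Open, going by these compounds, is whether 1,2-thiazol-4-yl would match 1,2-thiazol-5-yl at this place, and how a carboxylic acid or an amine there would read on the core of compound 1.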